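Phenyl for sec-butyl: what to expect of compound 4

The compounds below may be only part of what the source reports. "The series", "measured", "known", "first", "only" and "open" are said of these compounds alone.

Measured in a functional assay on HEL cells (Homo sapiens) for cytotoxicity; a higher number here means that more compound is tolerated, a lower number that less compound is tolerated:
Compound 1, `CCC(C)C1NC(=O)N(C2CCCC2)C1=O`, gives > 50 ug/mL.
Compound 2, `CCC(C)C(NC(=O)n1nnc2ccccc21)C(=O)NC1CCCCC1`, gives 76 ug/mL.
Compound 3, `CCC(C)C1NC(=O)N(Cc2ccccc2)C1=O`, gives 50 ug/mL.

Compound 1 stands at the limit of > 50 ug/mL in this assay, at which 1 of the 3 values shown sits; this is a limit of this assay, not a number. Compound 4, `O=C1NC(c2ccccc2)C(=O)N1C1CCCC1`, differs from compound 1 by phenyl in place of sec-butyl on a saturated ring carbon. Among the measured compounds shown here, no pair of the measured compounds differs in a single place, so no measured step guides this change. The step from compound 1 to compound 4 is expected to be a step that the limit leaves unreadable from compound 1 to compound 4, none beyond the usual scatter. Compound 4 is therefore estimated at 60 ug/mL, with a range from 30 ug/mL to 120 ug/mL.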

Compound 4, half-maximal cytotoxic concentration: 27.4 ug/mL
The estimate for compound 4 lay 2.2-fold (0.34 log units) above the measured number, outside the stated range (below it).
By their numbers in this assay, from the lowest: compounds 4, 3 and 2 (each within the scatter of the next, the first and the last beyond it).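

In this assay, among the compounds shown here, phenyl in place of sec-butyl on a saturated ring carbon gives the first step at this position, with an at least 1.8-fold lower number from compound 1 to compound 4 (0.26 log units; that floor lies within the scatter). Compound 4 gives 27.4 ug/mL, a number rather than a limit, so this position now has one measured value with a cyclopentyl group on the ring nitrogen. Compound 1 stands at a limit of the assay and not at a number, so the step has only a floor: the limit of > 50 ug/mL in this assay, at which 1 of the 4 values shown sits.

The compounds shown leave open how a methyl group or a carboxylic acid at this ring carbon would read. They also leave open whether an amine on the phenyl ring of compound 4 would shift its number.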